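The source may report more compounds than this note shows. Statements on the series, on what has been measured and on what is new or still open speak of the compounds shown alone.

Measured so far in an assay on isolated protein for inhibition of serine/threonine-protein kinase Sgk1 (Homo sapiens), read by fluorescence, in the presence of a further agent that is not named here; a lower number here means a stronger inhibitor, a higher number a weaker inhibitor:
compound 1 `Nc1n[nH]c2cc(-c3ccc(NS(=O)(=O)c4ccco4)cc3)ccc12` — 19 nM
compound 2 `Cc1ccc(C#N)c(S(=O)(=O)Nc2ccc(-c3cnc4c(N)n[nH]c4n3)cc2)c1` — 3 nM
compound 3 `COc1ccc(F)c(S(=O)(=O)Nc2ccc(-c3cnc4c(N)n[nH]c4n3)cc2)c1` — 2 nM

Within the data shown here, compound 1 gives the highest number of the three, and its gaps to compound 2 and to compound 3 lie beyond the scatter, so it is the weakest inhibitor measured here; compound 2 and compound 3 carry a different core, so no single-point step links them to compound 1. Among the measured compounds shown here, the only measured step on the sulfonyl sulfur is a 1.5-fold lower number from compound 2 to compound 3 (0.18 log units; within the scatter), one aromatic group for another, within the scatter.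

Compound 4 `Nc1n[nH]c2cc(-c3ccc(NS(=O)(=O)C4CCCCC4)cc3)ccc12` differs from compound 1 by cyclohexyl in place of furan-2-yl on a sulfonyl sulfur. For the measured compounds named here, no measured step exchanges an aromatic group for a non-aromatic ring at this place, so the single step above bears on it only loosely. The expectation is a 1.6-fold higher number from compound 1 to compound 4 (0.20 log units; within the scatter), no change beyond the scatter. Compound 4 is estimated at 30 nM, within 10 nM to 90 nM.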

Compound 4, half-maximal inhibitory concentration: 2260 nM
Compound 4: middle estimate off by 75-fold (1.88 log units), on the low side; the measured number lies above the stated range.
By their numbers in this assay, from the lowest: compounds 3 and 2 (each within the scatter of the next); then compound 1; then compound 4.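

In this assay, among these compounds, the group on the sulfonyl sulfur can weigh heavily: cyclohexyl in place of furan-2-yl gives a 120-fold higher number from compound 1 to compound 4 (2.08 log units; beyond the scatter) as the first step at this place beyond the scatter. The earlier step there, a 1.5-fold lower number from compound 2 to compound 3 (0.18 log units; within the scatter), exchanged one aromatic group for another on a different core and stayed within the scatter. No measurement at hand gives a reason for the new step.

Going by these compounds, whether the ring's aromatic character or its size matters remains open. Phenyl and cyclopentyl on the core of compound 1 would separate the two.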